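The compounds below may be only part of what the source reports. "The series", "measured", "known", "first", "only" and "open" are said of these compounds alone.

This piece follows one small change among compounds that share a core and were tested in a functional assay on HEK293 cells for positive allosteric modulation of metabotropic glutamate receptor 5 (Homo sapiens), read by calcium flux; a lower number here means a smaller maximal response, a higher number a larger maximal response. Compound 2, with the structure `CC(=O)N1CCCn2nc(CNc3ccccc3)cc21`, gives 20% in this assay. Going by the values given here, of the two compounds measured so far, compound 2 stands lowest. Among the compounds with values here, its only neighbour on the numbers is compound 1, `CC(=O)N1CCCn2nc(COc3cc(F)cc(F)c3)cc21`, which in this assay gives 63%, a gap that lies beyond the usual scatter of this kind of measurement. Compound 3, `CC(=O)N1CCCn2nc(CN(C)c3ccccc3)cc21`, has not yet been measured. It differs from compound 2 in one place: methyl in place of hydrogen on a nitrogen on an aromatic ring. Within the data shown here, no pair of measured compounds shows this kind of change, so there is no measured step to lean on; the only guide is where compound 2 sits, at the bottom of the two numbers, leaving more room upward than downward. The step is expected to be modest and upward, a number 10 percentage points higher from compound 2 to compound 3 (within the scatter), quite possibly within the scatter. Compound 3 is estimated to reach about 30% in this assay, with a likely range from 10% to 60%.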

Compound 3, largest response reached (reported as percent of maximum), in percent of the reference or control that the assay uses: 74%
Estimate against measurement, compound 3: 44 percentage points below; the measured number lies above the stated range.
By their numbers in this assay, from the lowest: compound 2; then compound 1; then compound 3.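

In this assay, methyl in place of hydrogen on a nitrogen on an aromatic ring gives a number 54 percentage points higher from compound 2 to compound 3 (beyond the scatter), so this nitrogen is a place where a very small edit can change the maximal response substantially. The change adds only 1 heavy atom, with no ring, no hydrogen-bond donor or acceptor and no net charge, and yet the step is large and lies beyond the usual scatter. Going by these compounds alone, this pair is the first to isolate this position, since compound 1 differs from compound 2 in more than one place, but nothing available accounts for the size of the step, which therefore remains an observation rather than an explanation.

A single step cannot show whether the response would keep rising, level off or fall with an ethyl group, a longer chain or an acetyl group on this nitrogen. It also leaves open whether methyl would produce a step of similar size on a related compound with a different aromatic ring, such as one carrying fluorine.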